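The compounds below may be only part of what the source reports. "The series", "measured", "known", "first", "only" and "open" are said of these compounds alone.

Of the compounds shown here, two that share one core have been tested in an assay on isolated protein for inhibition of DNA topoisomerase 1 (Homo sapiens), with a stated time of 30 min, tested at 20 uM; a higher number here means a stronger effect of the compound at the concentration tested, a lower number a weaker effect. Compound 1 `Oc1cccc(-c2cc(-c3ccccc3)nc(-c3cccs3)c2)c1` gives 2% in this assay, and compound 2 `Oc1cccc(-c2cc(-c3ccccc3)nc(-c3ccccn3)c2)c1` gives 2.8% in this assay. Going by the values given here, the single measured step, a number 0.8 percentage points higher from compound 1 to compound 2 (within the scatter), shows that putting pyridin-2-yl in place of thiophen-2-yl left the read-out essentially where it was. Compound 2 thus stands alongside compound 1, the two being indistinguishable within the scatter, and both sit near the bottom of what this read-out can show. Compound 3 `Oc1cccc(-c2cc(-c3ccccc3)nc(-c3cccnc3)c2)c1` differs from compound 2 as follows: pyridin-3-yl in place of pyridin-2-yl on an aromatic carbon. Among the compounds with values here, no measured step covers this exact change. Within the data shown here, the one step that exists, from compound 1 to compound 2, concerned the same group and was small, and nothing in the data suggests that moving to pyridin-3-yl would push the number far. A step of a number 0.2 percentage points higher from compound 2 to compound 3 (within the scatter) in this assay is therefore expected, that is, none beyond the scatter. Compound 3 is accordingly estimated to give 3% in this assay, with a range from 0% to 12%.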

Compound 3, a percentage reported as inhibition, at one concentration (the size of the read-out at that concentration, not a potency): 1.5%
Beside the measured number, compound 3's estimate is 1.5 percentage points above it; the range from low to high includes it.
By their numbers in this assay, from the lowest: compounds 3, 1 and 2 (each within the scatter of the next).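

The new compound asks something the first pair could not, since pyridin-2-yl and pyridin-3-yl have the same atoms and the same counts and differ only in how the ring is joined to the core. Even so, in this assay this change gives a number 1.3 percentage points lower from compound 2 to compound 3 (within the scatter), and the comparison with the five-membered group gives a number 0.5 percentage points lower from compound 1 to compound 3 (within the scatter), so all three aromatic rings placed next to the ring nitrogen leave the read-out indistinguishable and near the bottom of what it can show. Nothing further is available that could explain why the read-out stays so low with these groups.

As far as these compounds go, all three groups are aromatic rings, so it remains open whether something of a different kind at this place, such as an amine, a carboxylic acid or a longer alkyl chain, would move the number beyond the scatter. The 3-hydroxyphenyl and phenyl groups are also the same in all three compounds, which leaves open what replacing either of them, for instance the hydroxyl with a methoxy group, would do.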